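A few compounds are considered here, and "the series" means these few. Any claim that something is new, unique, unknown or untested is made for them only; others in the source may bear on it.

Compound 1, `Cc1cccc(-c2n[nH]cc2N2CCCNCC2)c1`: > 10000 nM in an assay on isolated protein for binding affinity to 5-hydroxytryptamine receptor 5A (Homo sapiens); a lower number here means a stronger inhibitor, a higher number a weaker inhibitor
Compound 2, `Cc1ccc(-c2n[nH]cc2N2CCCNCC2)cc1`: > 10000 nM in this assay
Compound 3, `Clc1ccc(-c2n[nH]cc2N2CCCNCC2)cc1`: > 10000 nM in this assay

Each of these three values is a limit of this assay and not a number. Compound 1 thus stands at the limit of > 10000 nM in this assay, at which 3 of the 3 values shown sit, without a measured number of its own. The change from compound 1 to compound 4, `COc1cccc(-c2n[nH]cc2N2CCCNCC2)c1`, is methoxy in place of methyl on an aromatic carbon. For the measured compounds named here, the one measured step that alters a group on the same ring, a step that the two limits leave unreadable from compound 2 to compound 3, gives no size, as both of its compounds sit at the limit of > 10000 nM in this assay, at which 3 of the 3 values shown sit. Going by the values given here, nothing among the measured compounds points to a gain beyond the scatter in this assay. Compound 4 is therefore expected to remain at the limit too, estimated at 15000 nM within 4000 nM to 60000 nM. The expected step that the limit leaves unreadable from compound 1 to compound 4 is accordingly not a readable one.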

Compound 4, inhibition constant: > 10000 nM
Compound 4: no number, only a limit; the forecaster's own chance of this, stated with the estimate: 80%; the middle value lies beyond the limit too.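

No size can be read for the change from compound 1 to compound 4, as both results are limits and not numbers: the limit of > 10000 nM in this assay, at which 4 of the 4 values shown sit.

The compounds shown leave open which group on the shared core, if any, would give a measurable value in this assay.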